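Removing the ester arm from compound 2

A few compounds are considered here, and "the series" means these few. Any claim that something is new, unique, unknown or untested is made for them only; others in the source may bear on it.

Among the compounds with values here, in a functional assay on HEL cells (Homo sapiens) (on this read-out lower numbers stand for higher toxicity in this test and higher numbers for lower toxicity in this test), compound 2 (`CCOC(=O)CNC(=O)NC1=CS(=O)(=O)O[C@@]12[C@@H](CO[Si](C)(C)C(C)(C)C)O[C@@H](n1cc(C)c(=O)n(C)c1=O)[C@@H]2O[Si](C)(C)C(C)(C)C`) gives 13000 nM as the only exact number so far. Compound 1 (`CC(=O)NC1=CS(=O)(=O)O[C@@]12[C@@H](CO[Si](C)(C)C(C)(C)C)O[C@@H](n1cc(C)c(=O)n(C)c1=O)[C@@H]2O[Si](C)(C)C(C)(C)C`) stands at > 200000 nM which is a limit of the assay and not a number. Compound 3 (`Cc1cn([C@@H]2O[C@H](CO[Si](C)(C)C(C)(C)C)[C@@]3(OS(=O)(=O)C=C3NC(N)=O)[C@H]2O[Si](C)(C)C(C)(C)C)c(=O)n(C)c1=O`) carries hydrogen in place of (ethoxycarbonyl)methyl on an amide-type nitrogen and so bears a ureido group.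

Within the data shown here, one measured step bears on this change. It is large: an at least 15-fold lower number from compound 1 to compound 2 (1.18 log units; beyond the scatter) with ((ethoxycarbonyl)methyl)amino in place of methyl on a carbonyl carbon. Because of an at least 15-fold lower number from compound 1 to compound 2 (1.18 log units; beyond the scatter) the loss of the (ethoxycarbonyl)methyl group, present in compound 2 and absent from compound 1, is expected to move the number in this assay back up. Among the measured compounds shown here, compound 3 keeps the amino part of that step, and no measured pair separates the amino part from the ester part, so only a partial return is expected. The expected change is a 6.2-fold higher number from compound 2 to compound 3 (0.79 log units; beyond the scatter) on this reasoning. For compound 3 the estimate is 80000 nM with an expected range from 20000 nM to 200000 nM and the assay may report only a limit.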

Compound 3, half-maximal cytotoxic concentration: 11000 nM
Compound 3: the middle estimate sits 7.3-fold (0.86 log units) above what was measured; the whole stated range lies above it.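

In this assay, the (ethoxycarbonyl)methyl group on the amide-type nitrogen is not required for the read-out: hydrogen in its place gives a 1.2-fold lower number from compound 2 to compound 3 (0.07 log units; within the scatter), so the ester arm of compound 2 shows no measurable share in the earlier large step. The large change instead goes with replacing methyl on the carbonyl carbon by a nitrogen group, since the plain ureido group alone already gives an at least 18-fold lower number from compound 1 to compound 3 (1.25 log units; beyond the scatter). Compound 1 is a limit of the assay and not a number, so the true size of this step remains a bound, set by this value: the limit of > 200000 nM in this assay, at which 1 of the 3 values shown sits.

Still open, on these data alone, is whether the ureido group is specifically required or whether any nitrogen substituent on the carbonyl carbon serves, which methylamino or dimethylamino in place of amino would separate. Also open, as far as these compounds go, is how far the number in this assay depends on the two tert-butyldimethylsilyl groups, which a free hydroxyl group at each of those places would test.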